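Aryl amide swap on the cyclopropane series: bromophenyl next

The compounds below may be only part of what the source reports. "The series", "measured", "known", "first", "only" and "open" are said of these compounds alone.

Measured so far in a functional assay on SiHa cells (Homo sapiens) for inhibition, read by CCK-8 assay, with a stated time of 72 h, tested at 1 uM; a lower number here means less inhibition of growth, a higher number more inhibition of growth at the concentration tested:
Compound 1 `CN(C)C(=O)c1cc2cnc(Nc3ccc(NC(=O)C4(C(=O)Nc5ccc(Cl)c(C(F)(F)F)c5)CC4)cc3)nc2n1C1CCCC1`: -11.2%
Compound 2 `Cc1ccc(NC(=O)C2(C(=O)Nc3ccc(Nc4ncc5cc(C(=O)N(C)C)n(C6CCCC6)c5n4)cc3)CC2)cc1`: 37%
Not yet measured: compound 3 `CN(C)C(=O)c1cc2cnc(Nc3ccc(NC(=O)C4(C(=O)Nc5cccc(Br)c5)CC4)cc3)nc2n1C1CCCC1`

Of the two measured compounds, compound 2 holds the higher number, and compound 1 lies beyond the scatter under it. The next step leaves the shared core untouched and changes only the aryl group: 3-bromophenyl in place of 4-methylphenyl on an amide-type nitrogen. In words, 3-bromophenyl stands in place of 4-methylphenyl on an amide-type nitrogen.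

Among the compounds with values here, one measured step bears on this, at the same place: a number 48.2 percentage points higher from compound 1 to compound 2 (beyond the scatter). It is large and beyond the scatter, and it came with 4-methylphenyl in place of 4-chloro-3-(trifluoromethyl)phenyl. Compound 3 carries a halogen on that phenyl, as compound 1 does, but it has a single substituent and no trifluoromethyl. A fall from compound 2 is therefore expected, probably smaller than the measured step, although one step is thin ground and a change within the scatter remains possible. The expected change is a number 22 percentage points lower from compound 2 to compound 3 (beyond the scatter). In this assay the estimate for compound 3 is 15%, with an expected range of -10% to 38%.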

Compound 3, percent growth inhibition at one concentration: 13.9%
The estimate for compound 3 lay 1.1 percentage points above the measured number, within the range that was stated.
By their numbers in this assay, from the lowest: compound 1; then compound 3; then compound 2.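

In this assay, this position gives three separated levels rather than two: a number 23.1 percentage points lower from compound 2 to compound 3 (beyond the scatter), and a number 25.1 percentage points higher from compound 1 to compound 3 (beyond the scatter). Within the data shown here, the 3-bromophenyl group therefore shows that a halogen on this phenyl does not by itself bring the number down to that of compound 1, although both halogen-bearing compounds remain under compound 2, with no compound among the three going against that order. Nothing measured here bears on why the three aryl groups fall in this order.

The step to compound 3 changes both the substituent and its place on the phenyl, so the contributions of the bromine and of its location cannot be separated from these compounds. Also open, from the compounds shown here alone, is how the series responds at this amide-type nitrogen to an unsubstituted phenyl, or to a phenyl carrying an amine or a carboxylic acid, groups that would show whether the 4-methylphenyl level of compound 2 can be matched or passed.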